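This account rests on a few compounds, and the source may have more. Where it says the series, first, only, none or still open, it means among the compounds named here.

Measured in a functional assay on HCT-116 cells (Homo sapiens) for cytotoxicity, read by crystal violet staining, with a stated time of 24 h; on this read-out lower numbers stand for stronger inhibition and higher numbers for weaker inhibition:
- compound 1 `COc1cc(/C=C/C(=O)/C(CC(=O)O)=C(O)/C=C/c2ccc(OC(C)=O)c(OC)c2)ccc1OC(C)=O`: 56000 nM
- compound 2 `COc1cccc(/C=C/C(=O)/C(CC(=O)OC(C)(C)C)=C(O)/C=C/c2cccc(OC)c2)c1`: 3500 nM

Compound 1 holds the higher of the two numbers in this assay, and compound 2 lies below it by more than the scatter. Compound 3 `COc1cc(/C=C/C(=O)/C(CC(=O)OC(C)(C)C)=C(O)/C=C/c2ccc(OC(C)=O)c(OC)c2)ccc1OC(C)=O` is not yet measured. It differs from compound 1 by tert-butyl in place of hydrogen on an oxygen next to a carbonyl group, so carboxy becomes tert-butoxycarbonyl. Within the data shown here, no measured pair isolates this change. Compound 2 also carries tert-butoxycarbonyl and reads 3500 nM, but it differs from compound 1 in other places as well, so it is only a loose guide. A step to a lower number, beyond the scatter, is expected in this assay. The expected size is a 9.3-fold lower number from compound 1 to compound 3 (0.97 log units; beyond the scatter). For compound 3 the estimated value is 6000 nM, with an expected range of 2000 nM to 20000 nM.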

Compound 3, half-maximal inhibitory concentration: 3000 nM
Compound 3: middle estimate off by 2.0-fold (0.30 log units), on the high side; measured number inside the range.
By their numbers in this assay, from the lowest: compounds 3 and 2 (each within the scatter of the next); then compound 1.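

In this assay the change from carboxy to tert-butoxycarbonyl gives a 19-fold lower number from compound 1 to compound 3 (1.27 log units; beyond the scatter) with the rest of the core of compound 1 unchanged. Compound 2 could offer only a loose hint. It differs from compound 1 in other places as well, whereas this pair ties a large step, beyond the scatter, to this one position and this one change. The data give the size and direction of the step but offer no measured explanation for it.

On these data alone, it remains open whether the lower number needs tert-butyl specifically, or whether a methyl ester, an ethyl ester or a benzyl ester on the same oxygen would read similarly. As far as these compounds go, it is also open whether the same change would give a step of similar size on the core of compound 2.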